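Hydrazone aryl variation on the fluorophenyl urea series

A few compounds are considered here, and "the series" means these few. Any claim that something is new, unique, unknown or untested is made for them only; others in the source may bear on it.

Measured so far:
compound 1 `COc1ccc(OC)c(/C=N/NC(=O)Nc2ccc(Oc3ccnc(-c4nncn4CCN(C)C)c3)c(F)c2)c1` — 6400 nM
compound 2 `COc1cc(/C=N/NC(=O)Nc2ccc(Oc3ccnc(-c4nncn4CCN(C)C)c3)c(F)c2)cc(OC)c1OC` — 22500 nM

In a functional assay on U-87MG ATCC cells (Homo sapiens) for cytotoxicity, read by MTT assay, with a stated time of 72 h (on this read-out higher numbers stand for weaker inhibition and lower numbers for stronger inhibition), compound 1 gives 6400 nM, while compound 2 gives 22500 nM. Among the measured compounds shown here, the single step between them, a 3.5-fold higher number from compound 1 to compound 2 (0.55 log units; beyond the scatter), is the only measured change, and it places compound 2 as the higher of the two numbers, with compound 1 as its nearest neighbour at a lower number. Compound 3 `CN(C)CCn1cnnc1-c1cc(Oc2ccc(NC(=O)N/N=C/c3c(O)ccc4ccccc34)cc2F)ccn1` is not yet measured. It differs from compound 2 by 2-hydroxynaphthalen-1-yl in place of 3,4,5-trimethoxyphenyl on a carbon with a double bond to nitrogen. For the measured compounds named here, no measured step bears directly on this change: the one step recorded, a 3.5-fold higher number from compound 1 to compound 2 (0.55 log units; beyond the scatter), swaps one methoxy-substituted phenyl for another, whereas compound 3 carries a two-ring aryl group with a hydroxyl in place of the methoxy groups. The range spanned by compounds 1 and 2 gives the only anchor, so a number for compound 3 is expected within that range or somewhat below it, with a step of a 3.8-fold lower number from compound 2 to compound 3 (0.57 log units; beyond the scatter) expected. Compound 3 is therefore estimated at 6000 nM in this assay, with a range from 1500 nM to 25000 nM.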

Compound 3, half-maximal inhibitory concentration: 620 nM
Compound 3: middle estimate off by 9.7-fold (0.99 log units), on the high side; measured number outside the range, below it.
By their numbers in this assay, from the lowest: compound 3; then compound 1; then compound 2.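

In this assay, the position on a carbon with a double bond to nitrogen proves more sensitive than the methoxy-substituted phenyl pair suggested: the step to 2-hydroxynaphthalen-1-yl is (a 36-fold lower number from compound 2 to compound 3 (1.56 log units; beyond the scatter)) against 3,4,5-trimethoxyphenyl and (a 10-fold lower number from compound 1 to compound 3 (1.01 log units; beyond the scatter)) against 2,5-dimethoxyphenyl, both larger than the earlier (a 3.5-fold higher number from compound 1 to compound 2 (0.55 log units; beyond the scatter)). The lowest number of the three now belongs to compound 3, so a methoxy-substituted phenyl is not required here for activity in this cell read-out, and the two-ring aryl group with a hydroxyl outperforms both phenyls. No measurement on hand accounts for the size of this gain.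

The change alters several things at once, replacing one six-membered aromatic ring with two and the methoxy groups with a hydroxyl, so the contribution of each remains unresolved. An unsubstituted naphthalen-1-yl and a 2-hydroxyphenyl would separate the second ring from the hydroxyl, while a 2-methoxynaphthalen-1-yl would show whether the free hydroxyl hydrogen matters at this position.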